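A few compounds are considered here, and "the series" means these few. Any claim that something is new, unique, unknown or untested is made for them only; others in the source may bear on it.

Measured so far, in an ADME assay on HEp-2 cells (Homo sapiens) for cytotoxicity, read by MTT assay, with a stated time of 3 days; a higher number here means that more compound is tolerated, a lower number that less compound is tolerated:
- compound 1, `CC[C@@H](CCn1cncn1)c1ccc(F)cc1`, gives 90.3 ug/mL
- compound 2, `CC[C@H](CCn1cncn1)c1ccc(C)cc1`, gives 75.2 ug/mL
- compound 3, `CC[C@@H](CCn1cncn1)c1ccc(C)cc1`, gives 69.9 ug/mL

Compound 3 stands at the lowest of the three numbers, but the distance is small: the step of a 1.3-fold lower number from compound 1 to compound 3 (0.11 log units; within the scatter) and the step of a 1.1-fold lower number from compound 2 to compound 3 (0.03 log units; within the scatter) both fall within the scatter, and the latter concerns two compounds that share all atoms and bonds because of the fact that compounds 2 and 3 differ only in the configuration as drawn.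

Compound 4, `CCCC[C@@H](CCn1cncn1)c1ccc(C)cc1`, is not yet measured. Its difference from compound 3 is ethyl in place of hydrogen on a saturated chain carbon, three bonds along the chain from an aromatic carbon. Neither measured step touches this place on the saturated chain: one changes an aromatic substituent, the other only the configuration as drawn, and both were within the scatter. Going by the values given here, there is thus no measured step on which to build an expectation of a change in this assay beyond the scatter, in either direction.

For compound 4 the expected value in this assay is 55 ug/mL, within 30 ug/mL to 100 ug/mL, which means an expected step of a 1.3-fold lower number from compound 3 to compound 4 (0.10 log units; within the scatter).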

Compound 4, half-maximal cytotoxic concentration: 60.7 ug/mL
Compound 4: middle estimate off by 1.1-fold (0.04 log units), on the low side; measured number inside the range.
By their numbers in this assay, from the lowest: compounds 4, 3, 2 and 1 (each within the scatter of the next).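

Going by these compounds alone, compound 4 gives the first reading at this place, a saturated chain carbon three bonds along the chain from an aromatic carbon: in this assay, ethyl in place of hydrogen gives a 1.2-fold lower number from compound 3 to compound 4 (0.06 log units; within the scatter). Lengthening ethyl to butyl here therefore leaves the tolerated concentration within the scatter, as the earlier steps at the aromatic substituent and in the configuration as drawn had done at their own places. Nothing in the available evidence bears on why this chain change gives so small a step.

Going by these compounds, it remains open whether a longer chain, an amine or a carboxylic acid at this carbon would give a step beyond the scatter. On these data alone, it is also open whether the butyl compound would read the same with its stereocentre drawn the other way.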